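Fluoro for nitro: from compound 3 to compound 4

The source may hold more compounds than are shown below. What is called first, only, known or untested is meant among the compounds shown, and "the series" means these compounds.

The series shares one core and varies only the aryl group. In a functional assay on PC-3 cells (Homo sapiens) for cytotoxicity, read by sulforhodamine B assay, with a stated time of 48 h (on this read-out lower numbers stand for stronger inhibition and higher numbers for weaker inhibition), compound 1 (`C[C@H]1CC[C@@H]2[C@@H](OC(=O)[C@]23CC(c2ccc(Cl)cc2)=NO3)[C@]2(C)C(=O)C=C[C@@]12O`) gives 49000 nM, compound 2 (`C[C@H]1CC[C@@H]2[C@@H](OC(=O)[C@]23CC(c2ccccc2Br)=NO3)[C@]2(C)C(=O)C=C[C@@]12O`) gives 51000 nM and compound 3 (`C[C@H]1CC[C@@H]2[C@@H](OC(=O)[C@]23CC(c2ccccc2[N+](=O)[O-])=NO3)[C@]2(C)C(=O)C=C[C@@]12O`) gives 37000 nM. Compound 3 therefore stands level with the other two, within the scatter of each.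

The next compound, compound 4 (`C[C@H]1CC[C@@H]2[C@@H](OC(=O)[C@]23CC(c2ccccc2F)=NO3)[C@]2(C)C(=O)C=C[C@@]12O`), differs from compound 3 as follows: fluoro in place of nitro on an aromatic carbon. In words, this is fluoro in place of nitro on an aromatic carbon, ortho to a large group.

The closest measured change is at the same place, a 1.4-fold lower number from compound 2 to compound 3 (0.14 log units; within the scatter). The two changes of the whole aryl group are a 1.0-fold higher number from compound 1 to compound 2 (0.02 log units; within the scatter) and a 1.3-fold lower number from compound 1 to compound 3 (0.12 log units; within the scatter). Among the compounds with values here, all three measured steps stay within the scatter, and no compound among the three goes against that. Within the data shown here, no fluoro compound has been measured yet, so this flatness is the only guide, and it covers just three compounds.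

In this assay no step beyond the scatter is expected, and no direction is favoured. The estimated step is a 1.2-fold higher number from compound 3 to compound 4 (0.08 log units; within the scatter). For compound 4 the expected value is 44000 nM, with an estimated range of 25000 nM to 75000 nM.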

Compound 4, half-maximal inhibitory concentration: 8200 nM
Beside the measured number, compound 4's estimate is 5.4-fold (0.73 log units) above it; the whole stated range lies above it.
By their numbers in this assay, from the lowest: compound 4; then compounds 3, 1 and 2 (each within the scatter of the next).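

In this assay the aryl group is no longer flat: fluoro in place of nitro gives a 4.5-fold lower number from compound 3 to compound 4 (0.65 log units; beyond the scatter), and fluoro in place of bromo on the same aromatic carbon gives a 6.2-fold lower number from compound 2 to compound 4 (0.79 log units; beyond the scatter), so this position does respond to the group it carries, which the three earlier compounds, all level within the scatter, did not show. The change of the whole aryl group gives a 6.0-fold lower number from compound 1 to compound 4 (0.78 log units; beyond the scatter), which puts compound 4 apart from all three others, each step beyond the scatter though modest, while the 2-nitrophenyl, 2-bromophenyl and 4-chlorophenyl compounds remain level with one another. Nothing available here accounts for the lower number of the 2-fluorophenyl compound.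

As far as these compounds go, whether that lower number belongs to fluoro alone stays open, and a plain hydrogen, a methoxy group, an amine or a nitrile on the same aromatic carbon would test it. Also open, from the compounds shown here alone, is whether fluoro on another carbon of the same aromatic ring keeps the step, since a single fluoro compound cannot separate the group from its place.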